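Chloro for trifluoromethyl on the terminal aryl ring

This account rests on a few compounds, and the source may have more. Where it says the series, first, only, none or still open, it means among the compounds named here.

Measured so far:
compound 1, `COc1cc2cc(Oc3ccc(NC(=O)Nc4cccc(C(F)(F)F)c4)cc3)c(C)nc2cc1OC`: > 50000 nM, a limit of the assay
compound 2, `COc1cc2cc(Oc3ccc(NC(=O)Nc4ccc(Cl)c(C(F)(F)F)c4)cc3)c(C)nc2cc1OC`: 5480 nM

Going by the values given here, in a functional assay on HCC 2998 cells (Homo sapiens) for inhibition, read by sulforhodamine B assay, with a stated time of 48 h (on this read-out lower numbers stand for stronger inhibition of growth and higher numbers for weaker inhibition of growth), compound 2 holds the only real number; the value of compound 1 is a limit (the limit of > 50000 nM in this assay, at which 1 of the 2 values shown sits). Among the compounds with values here, the single measured step, an at least 9.1-fold lower number from compound 1 to compound 2 (0.96 log units; beyond the scatter), came from adding chloro on an aromatic carbon. Compound 3, `COc1cc2cc(Oc3ccc(NC(=O)Nc4ccc(Cl)c(Cl)c4)cc3)c(C)nc2cc1OC`, differs from compound 2 by chloro in place of trifluoromethyl on an aromatic carbon. Within the data shown here, no measured step swaps trifluoromethyl for chloro, so the measured step gives no direct guide; the change is expected to stay within the scatter, a 1.1-fold higher number from compound 2 to compound 3 (0.04 log units; within the scatter). Compound 3 is estimated at 6000 nM, between 2000 nM and 20000 nM.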

Compound 3, concentration for total growth inhibition: > 100000 nM
Compound 3 gave a limit, no number (the forecaster's own chance of this, stated with the estimate: 10%); middle value at least 16-fold (1.22 log units) away from the limit.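

Chloro in place of trifluoromethyl, on the aromatic carbon ortho to a chloro group, is poorly tolerated in this assay, giving an at least 18-fold higher number from compound 2 to compound 3 (1.26 log units; beyond the scatter). Of the three compounds, only compound 2, which carries both chloro and trifluoromethyl on the terminal aryl ring, gives a real number. The value of compound 3 is a limit: the limit of > 100000 nM in this assay, at which 1 of the 3 values shown sits.

The step from compound 1 to compound 3 cannot be read, as both values are limits. As far as these compounds go, whether a nitrile or a methoxy group at this position would keep the growth inhibition of compound 2 remains open.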